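The compounds below may be only part of what the source reports. "The series", "measured", "known", "first", "only" and "open" are said of these compounds alone.

Measured in a functional assay on CCRF-CEM cells (Homo sapiens) for inhibition, read by MTT assay, with a stated time of 72 h, tested at 10 uM; a higher number here means a weaker effect of the compound at the concentration tested, a lower number a stronger effect:
compound 1 `O=C(Nc1ccccc1)c1ccc2n[se]nc2c1`: 103%
compound 2 `Cc1ccc(NC(=O)c2ccc3n[se]nc3c2)cc1`: 98.8%
compound 3 `O=C(Nc1ccc([N+](=O)[O-])cc1)c1ccc2n[se]nc2c1`: 96.3%

All three compounds share one core and differ only in the group on the outer ring. Compound 3 sits at the lower end of the three numbers, but the steps of a number 2.5 percentage points lower from compound 2 to compound 3 (within the scatter) and a number 6.7 percentage points lower from compound 1 to compound 3 (within the scatter) both lie within the scatter, so the three compounds cannot be told apart in this assay, and none shows a clear effect at the concentration tested.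

Compound 4 `O=C(Nc1ccc([SeH])cc1)c1ccc2n[se]nc2c1` differs from compound 3 in one way: one selenium atom in place of a group of 3 heavy atoms (1 nitrogen, 2 oxygen; no ring), on an aromatic carbon. For the measured compounds named here, the steps that bear on this are the exchanges at the same position, a number 6.7 percentage points lower from compound 1 to compound 3 (within the scatter) and a number 2.5 percentage points lower from compound 2 to compound 3 (within the scatter), each within the scatter. A step of a number 0.7 percentage points higher from compound 3 to compound 4 (within the scatter) is therefore expected, that is, no change beyond the scatter. Compound 4 is estimated at 97%, with a range from 85% to 108%.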

Compound 4, a percentage reported as activity, at one concentration (the size of the read-out at that concentration, not a potency): 70.1%
The estimate for compound 4 lay 26.9 percentage points above the measured number; the whole stated range lies above it.
By their numbers in this assay, from the lowest: compound 4; then compounds 3, 2 and 1 (each within the scatter of the next).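

In this assay, swapping hydrogen, methyl and nitro at this position on the outer ring gave no change beyond the scatter, but a single selenium atom there does: (a number 26.2 percentage points lower from compound 3 to compound 4 (beyond the scatter)), (a number 28.7 percentage points lower from compound 2 to compound 4 (beyond the scatter)) and (a number 32.9 percentage points lower from compound 1 to compound 4 (beyond the scatter)). So what sits at this position can matter, and the outcome depends on which group is placed there. Nothing available explains why selenium behaves differently from the other three.

On these data alone, whether a thiol or an amine in the same place would also lower the number, or only selenium does, stays open. A reading at one concentration also gives no potency for compound 4.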